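This account rests on a few compounds, and the source may have more. Where it says the series, first, only, none or still open, it means among the compounds named here.

Measured in a functional assay on ASK cells (Rattus norvegicus) for cytotoxicity, read by sulforhodamine B assay; a higher number here means that more compound is needed for the effect, a lower number that less compound is needed:
- compound 1 `C=C1CC[C@@H]2[C@](C)(CO[Si](c3ccccc3)(c3ccccc3)C(C)(C)C)[C@H](OC(C)=O)CC[C@@]2(C)[C@@H]1C/C=C1/C(=O)OC[C@H]1O`: 10.5 uM
- compound 2 `C=C1CC[C@@H]2[C@](C)(CO[Si](C)(C)C(C)(C)C)[C@H](O)CC[C@@]2(C)[C@@H]1C/C=C1/C(=O)OC[C@H]1OC(C)=O`: 3.41 uM
- compound 3 `C=C1CC[C@@H]2[C@](C)(CO[Si](C)(C)C(C)(C)C)[C@H](O)CC[C@@]2(C)[C@@H]1C/C=C1/C(=O)OC[C@H]1O`: 15.5 uM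

Compound 1, at 10.5 uM, lies within the usual scatter of compound 3, at 15.5 uM. Compound 2, at 3.41 uM, has a clearly lower number than either.

Compound 4 `C=C1CC[C@@H]2[C@](C)(CO[Si](c3ccccc3)(c3ccccc3)C(C)(C)C)[C@H](O)CC[C@@]2(C)[C@@H]1C/C=C1/C(=O)OC[C@H]1O` follows from compound 1 by one change: hydrogen in place of acetyl on an oxygen on a saturated carbon. In words, hydrogen stands in place of acetyl on an oxygen on a saturated carbon whose other neighbours are a saturated ring carbon, so acetoxy becomes hydroxy.

Among the compounds with values here, one measured step bears on this, a 4.5-fold higher number from compound 2 to compound 3 (0.66 log units; beyond the scatter), which also puts hydrogen in place of acetyl and lies beyond the scatter. It is only a partial guide, since the acetyl lost there sits on a different oxygen and the silyl ether also differs from that of compound 1. Compound 3, at 15.5 uM, has the same free hydroxy groups as compound 4 and differs from it only in the silyl ether, which points the same way. A rise in the number is therefore expected, though a smaller one than the measured step. The expected step is a 1.9-fold higher number from compound 1 to compound 4 (0.28 log units; within the scatter). For compound 4 the estimate is 20 uM, with an expected range from 9 uM to 45 uM.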

Compound 4, concentration for half-maximal effect: 5.54 uM
Compound 4: the middle estimate sits 3.6-fold (0.56 log units) above what was measured, outside the stated range (below it).
By their numbers in this assay, from the lowest: compounds 2, 4, 1 and 3 (each within the scatter of the next, the first and the last beyond it).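

In this assay, putting hydrogen in place of acetyl on this oxygen gives a 1.9-fold lower number from compound 1 to compound 4 (0.28 log units; within the scatter), so on this evidence the acetoxy and hydroxy forms at this position cannot be told apart. Within the data shown here, the earlier compounds offered only one example of this exchange, a 4.5-fold higher number from compound 2 to compound 3 (0.66 log units; beyond the scatter), and that example could have suggested that losing an acetyl generally raises the number. The new pair shows that it does not carry over from one acetyl position and silyl ether to the other, and the outcome of the exchange depends on where it is made and on the surrounding compound: the two results differ by more than repeated measurements would explain, as the comparison shows: the same change on two cores in this assay, a 4.5-fold higher number (0.66 log units; beyond the scatter) from compound 2 to compound 3 and a 1.9-fold lower number (0.28 log units; within the scatter) from compound 1 to compound 4, 8.6-fold (0.94 log units) apart, beyond the scatter of two such steps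

What stays unresolved is which difference matters, since the two pairs differ both in the oxygen that carries the acetyl and in the silyl ether, and the compounds shown do not separate these two. Nor do they show how a benzoyl group or a methyl ether on this oxygen would compare with the acetyl and the hydrogen.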